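The source may hold more compounds than are shown below. What is called first, only, known or untested is meant among the compounds shown, and "the series" means these compounds.

Compound 1 `Cc1ccc2ncc(S(=O)(=O)c3cccc(C#N)c3)c(N3CCC(C)CC3)c2c1` and compound 2 `COc1ccc2ncc(S(=O)(=O)c3cccc(C#N)c3)c(N3CCC(C)CC3)c2c1` share one core and differ in a single place. In an assay on isolated protein for displacement of a labelled ligand from metabotropic glutamate receptor 5 (Homo sapiens), with a stated time of 60 min, tested at 1 uM (a higher number here means more inhibition at the concentration tested (going by the name of the read-out), a lower number less inhibition), compound 1 gives 52%, the lower of the two numbers, and compound 2 gives 90%. Among the compounds with values here, the only measured step, a number 38 percentage points higher from compound 1 to compound 2 (beyond the scatter), is large, but it concerns a methoxy in place of methyl on the core and nothing else.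

Compound 3 `Cc1ccc2ncc(S(=O)(=O)c3cccc(Cl)c3)c(N3CCC(C)CC3)c2c1` differs from compound 1 elsewhere: chloro in place of cyano on an aromatic carbon. Within the data shown here, no measured step touches the 3-cyanophenyl group, so the methoxy-for-methyl step offers no guide to it. With nothing to lean on, the account expects no step beyond the scatter, while allowing wide uncertainty in either direction.

For compound 3 in this assay the estimate is 50%, expected to lie between 25% and 75%. That estimate means an expected step of a number 2 percentage points lower from compound 1 to compound 3 (within the scatter).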

Compound 3, a percentage reported as inhibition, at one concentration (the size of the read-out at that concentration, not a potency): 91%
Estimate against measurement, compound 3: 41 percentage points below; the measured number lies above the stated range.
By their numbers in this assay, from the lowest: compound 1; then compounds 2 and 3 (each within the scatter of the next).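

Compound 1 shows that the 3-cyanophenyl group is not a silent part of this series: with the rest of the molecule unchanged, going to 3-chlorophenyl, with chloro in place of cyano on an aromatic carbon meta to a large group, gives a number 39 percentage points higher from compound 1 to compound 3 (beyond the scatter) in this assay. This place therefore responds to a single change with a large step, as does the place on the core where methoxy replaces methyl, which gives a number 38 percentage points higher from compound 1 to compound 2 (beyond the scatter). Nothing available explains why the chloro group reads so differently from the cyano group.

The compounds shown leave open how an amine, a carboxylic acid or a trifluoromethyl group would read at this same place. They also leave open what the chloro and methoxy groups would give together on the shared core.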